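Pyrimidinyl for pyridinyl on the ring amide nitrogen

This account rests on a few compounds, and the source may have more. Where it says the series, first, only, none or still open, it means among the compounds named here.

Compound 2 `CO[C@@H]1CC=C2NN(c3cccnc3)C(=O)C[C@]2(C)O1` gives in a functional assay on SK-N-SH cells (Homo sapiens) for inhibition, read by sulforhodamine B assay, with a stated time of 48 h (on this read-out higher numbers stand for weaker inhibition and lower numbers for stronger inhibition), a value of 19000 nM. Compound 1 `COc1ccc(N2NC3=CC[C@@H](OC)O[C@@]3(c3ccccc3)CC2=O)cc1` gives 10400 nM in this assay, and compound 3 `CO[C@@H]1CC=C2NN(c3cc4ccccc4[nH]3)C(=O)C[C@]2(c2ccccc2)O1` gives 9100 nM. Compound 2 thus holds the highest number of the three, though its gap to compound 1 is within the scatter, while its gap to compound 3 lies beyond it. Compound 4 `CO[C@@H]1CC=C2NN(c3cncnc3)C(=O)C[C@]2(C)O1` is not yet measured; it differs from compound 2 by pyrimidin-5-yl in place of pyridin-3-yl on an amide-type nitrogen in a ring. Within the data shown here, no measured step exchanges pyridin-3-yl for pyrimidin-5-yl. Among the measured compounds shown here, the only step at the same nitrogen, a 1.1-fold lower number from compound 1 to compound 3 (0.06 log units; within the scatter), shows that a different aryl group on that position left the number essentially unchanged. On that evidence the expected step is a 1.1-fold higher number from compound 2 to compound 4 (0.02 log units; within the scatter), that is, none beyond the scatter. Compound 4 is therefore estimated at 20000 nM in this assay, within a range from 8000 nM to 50000 nM.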

Compound 4, half-maximal inhibitory concentration: 16600 nM
Estimate against measurement, compound 4: 1.2-fold (0.08 log units) above; the range from low to high includes it.
By their numbers in this assay, from the lowest: compounds 3, 1, 4 and 2 (each within the scatter of the next, the first and the last beyond it).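

In this assay the exchange of pyridin-3-yl for pyrimidin-5-yl gives a 1.1-fold lower number from compound 2 to compound 4 (0.06 log units; within the scatter) and so adds a second hetero atom to the aromatic ring on the amide-type nitrogen without a change beyond the scatter. The earlier step at this nitrogen, a 1.1-fold lower number from compound 1 to compound 3 (0.06 log units; within the scatter) on the core of compound 1, exchanged one aryl group for a larger one; the present step extends the same flat reading to the core of compound 2, which carries the methyl group, and to a change of a single ring atom. No measurement at hand accounts for this result.

All groups shown at this nitrogen are aromatic rings, so a piperidine ring, a carboxylic acid or a plain butyl chain there remains untested. Also open, going by these compounds, is whether the flat reading holds for other hetero atoms in this ring, such as the sulfur of a thiophene.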